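The source may report more compounds than this note shows. Statements on the series, on what has been measured and on what is new or still open speak of the compounds shown alone.

Working notes on the series, following the step to compound 4.

In a toxicity assay on HEK-293T cells (Homo sapiens) for inhibition, read by MTT assay, with a stated time of 24 h (a higher number here means that more compound is tolerated, a lower number that less compound is tolerated), compound 3 `O=c1oc2ccccc2c(N2CCN(c3cccc(Cl)c3)CC2)c1CO` stands at > 50000 nM which is a limit and not a number. Compound 1 `COc1ccccc1N1CCN(c2c(CO)c(=O)oc3ccccc23)CC1` gives > 50000 nM which is likewise a limit. Compound 2 `COc1ccc(N2CCN(c3c(CO)c(=O)oc4ccccc34)CC2)cc1` gives > 50000 nM which is also a limit. For the measured compounds named here, the series so far therefore stands at the limit of > 50000 nM in this assay, at which 3 of the 3 values shown sit, with no compound going against that pattern.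

The next change leads to compound 4 `CCN1CCN(c2c(CO)c(=O)oc3ccccc23)CC1` and reads ethyl in place of 3-chlorophenyl on an amine nitrogen in a ring with ethyl in place of 3-chlorophenyl on an amine nitrogen in a ring. Going by the values given here, three measured steps change the group at that same nitrogen: a step that the two limits leave unreadable from compound 1 to compound 2 together with a step that the two limits leave unreadable from compound 1 to compound 3 and a step that the two limits leave unreadable from compound 2 to compound 3 as the only guides. None of them has a readable size, and none brings in ethyl, so they set no firm scale for this change.

No large step is expected in this assay given that compound 3 holds > 50000 nM as a limit. The read-out for compound 4 will most likely be a limit again. The expected change is a number no higher from compound 3 to compound 4 (the limit leaves the size open) as an estimate only. For compound 4 the estimate is 50000 nM with an expected range from 20000 nM to 100000 nM in the measurement to come.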

Compound 4, half-maximal cytotoxic concentration: > 50000 nM
Compound 4: only a limit was reported; the forecaster's own chance of this, stated with the estimate: 85%; the middle value lies on the limit itself.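

No new step can be read: the steps to compound 4 from compound 1, compound 2 and compound 3 each join two limits, so their sizes stay unreadable. In this assay the series stands at a single limit: the limit of > 50000 nM in this assay, at which 4 of the 4 values shown sit.

The compounds shown leave open whether any of the four differs from another in this assay and what concentration any of them tolerates before toxicity appears.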